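From methyl to 2-iodoethenyl: a step without a measured guide

This account rests on a few compounds, and the source may have more. Where it says the series, first, only, none or still open, it means among the compounds named here.

In a functional assay on Vero cells (Chlorocebus sabaeus) for cytotoxicity (a lower number here means that less compound is tolerated, a higher number that more compound is tolerated), compound 1 (`Nc1nc(O)c2ncn(C[C@]3(CO)C[C@H]3CO)c2n1`) gives 240 ug/mL as a number. Compound 2 (`O=c1ccn(CC2(CO)CC2CO)c(=O)[nH]1`) reaches only a limit, > 500 ug/mL, of the assay. Compound 3 (`Cc1cn(CC2(CO)CC2CO)c(=O)[nH]c1=O`) also reaches only a limit, > 500 ug/mL, of the assay. This is the limit of > 500 ug/mL in this assay, at which 2 of the 3 values shown sit, so compound 3 has no number of its own.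

Compound 4 (`O=c1[nH]c(=O)n(CC2(CO)CC2CO)cc1/C=C/I`) carries 2-iodoethenyl in place of methyl on an aromatic carbon. Among the measured compounds shown here, the only measured step, a step that the two limits leave unreadable from compound 2 to compound 3, offers no size to carry over. In this assay a modest fall or no readable change is therefore expected, with an at least 1.3-fold lower number from compound 3 to compound 4 (0.11 log units; that floor lies within the scatter) as the estimated step. Compound 4 is estimated at 380 ug/mL, within a range of 150 ug/mL to 800 ug/mL, and could again report only a limit.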

Compound 4, half-maximal cytotoxic concentration: 330 ug/mL
The estimate for compound 4 lay 1.2-fold (0.06 log units) above the measured number; the range from low to high includes it.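

In this assay compound 4 gives this aromatic carbon its first number, 330 ug/mL. With 2-iodoethenyl, the change reads as an at least 1.5-fold lower number from compound 3 to compound 4 (0.18 log units; that floor lies within the scatter), and as an at least 1.5-fold lower number from compound 2 to compound 4 (0.18 log units; that floor lies within the scatter). Both steps remain floors because compounds 2 and 3 carry no number of their own: the limit of > 500 ug/mL in this assay, at which 2 of the 4 values shown sit.

On these data alone, whether plain ethenyl, without iodine, would read like compound 4 stays open. So does the reading of an amine, a carboxylic acid or a longer alkyl chain on this aromatic carbon.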